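The compounds below may be only part of what the source reports. "The series", "measured", "known", "first", "only" and "open" are said of these compounds alone.

In a functional assay on NCI-H1581 cells (Homo sapiens) for inhibition, read by MTT assay, with a stated time of 48 h, tested at 10 uM (on this read-out higher numbers stand for more inhibition at the one concentration tested (going by the name of the read-out) and lower numbers for less inhibition), compound 1 `CCc1ccc(Nc2cc(NC(=O)Nc3cc(OC)cc(OC)c3)ncn2)cc1` gives 32.7%, the lower of the two numbers in hand. Compound 2 `COc1ccc(C(F)(F)F)cc1Nc1cc(NC(=O)Nc2c(Cl)cccc2Cl)ncn1` gives 69.1%, a number beyond the scatter above it. Compound 3 `COc1cc(NC(=O)Nc2cc(Nc3cc(I)ccc3OC)ncn2)cc(OC)c1` differs from compound 1 by 5-iodo-2-methoxyphenyl in place of 4-ethylphenyl on a nitrogen on an aromatic ring. For the measured compounds named here, no measured pair isolates this change, so the expectation rests on compound 1 alone and on the spread the two numbers show. A moderate rise in this assay is expected, a number 12.3 percentage points higher from compound 1 to compound 3 (beyond the scatter), though a step within the scatter would not surprise. Compound 3 is accordingly estimated at 45%, within the range 25% to 65%.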

Compound 3, a percentage reported as inhibition, at one concentration (the size of the read-out at that concentration, not a potency): 59%
For compound 3 the middle estimate is 14 percentage points below the measured one; measured number inside the range.
By their numbers in this assay, from the lowest: compound 1; then compound 3; then compound 2.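

In this assay the group on the nitrogen is a position that responds: 5-iodo-2-methoxyphenyl in place of 4-ethylphenyl gives a number 26.3 percentage points higher from compound 1 to compound 3 (beyond the scatter), with the rest of the molecule unchanged. This single step swaps the ethyl for both a methoxy and an iodine, so it cannot assign the rise to either substituent. Nothing available explains the rise.

Still open, as far as these compounds go, is what the methoxy and the iodine each contribute alone. Also open, from the compounds shown here alone, is how an amine or a carboxylic acid in place of the iodine would read.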